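The source may report more compounds than this note shows. Statements on the series, on what has been measured and on what is new or still open speak of the compounds shown alone.

Measured in an ADME assay on L1210/0 cells (Mus musculus) for cytotoxicity, with a stated time of 48 h; a higher number here means a weaker inhibitor, a lower number a stronger inhibitor:
- Compound 1 `COc1ncnc2c1ncn2C[C@@H]1C[C@H](O)c2ccccc21`: > 200000 nM
- Compound 2 `COC1=C(OC)/C(=C/Cn2cnc3c(Cl)ncnc32)OC1=O`: 14000 nM
- Compound 3 `CC1=C(C)C(=O)C(c2cn([C@H]3C[C@H](O)[C@@H](CO)O3)c(=O)[nH]c2=O)=C(C)C1=O`: 174000 nM

Compound 1 gives > 200000 nM, which is a limit of the assay and not a number. Of the two true numbers, compound 3 has the higher, 174000 nM, which makes it the weaker inhibitor of the pair, while compound 2 gives 14000 nM. The gap between these two compounds lies clearly beyond the scatter. Compound 4 `CC1=C(C)C(=O)C(c2cn([C@H]3C[C@H](O)[C@@H](CO)O3)c(=O)[nH]c2=O)=CC1=O` has hydrogen in place of methyl on a double-bonded ring carbon. For the measured compounds named here, no measured pair shows this change, so the expectation is loose: a modest move toward a lower number in this assay, near the edge of the scatter. The expected change is a 1.9-fold lower number from compound 3 to compound 4 (0.29 log units; within the scatter). For compound 4 the estimated value is 90000 nM, with an expected range of 25000 nM to 200000 nM.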

Compound 4, half-maximal inhibitory concentration: 112000 nM
The estimate for compound 4 lay 1.2-fold (0.09 log units) below the measured number; low and high end bracket the measured number.
By their numbers in this assay, from the lowest: compound 2; then compounds 4 and 3 (each within the scatter of the next). At a limit, above all of these: compound 1.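

Hydrogen in place of methyl on a double-bonded ring carbon now has a direct reading (a 1.6-fold lower number from compound 3 to compound 4 (0.19 log units; within the scatter)). In this assay this single change, next to the ring atom that bears a large group, therefore does not separate the two compounds. Compound 1 stands at a limit of the assay and not at a number: the limit of > 200000 nM in this assay, at which 1 of the 4 values shown sits.

The compounds shown leave open whether an ethyl, methoxy or amine group at this carbon would move the number. They also leave open whether replacing the other ring methyl groups would do so.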